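A few compounds are considered here, and "the series" means these few. Any claim that something is new, unique, unknown or untested is made for them only; others in the source may bear on it.

The study examines a small set of compounds that share one core. Compound 1 `COc1cc2nc(N3CCN(c4cnccn4)CC3)nc(N)c2cc1OC` gives 0.18 nM in an assay on brain for binding affinity to Adrenergic receptor alpha-1 (Rattus norvegicus); a lower number here means a stronger inhibitor, a higher number a weaker inhibitor. Compound 2 `COc1ccnc(N2CCN(c3nc(N)c4cc(OC)c(OC)cc4n3)CC2)n1` gives 0.19 nM in this assay. For the measured compounds named here, the one recorded step, a 1.1-fold higher number from compound 1 to compound 2 (0.02 log units; within the scatter), is the only comparison available, and it leaves compound 2 indistinguishable from compound 1 within the scatter; compound 2 thus stands as one of two closely matched measured compounds.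

Compound 3 `CCCOc1ccnc(N2CCN(c3nc(N)c4cc(OC)c(OC)cc4n3)CC2)n1` differs from compound 2 by ethyl in place of hydrogen on a saturated chain carbon bound to an oxygen on an aromatic ring. Going by the values given here, no measured step bears on a change of this kind: the recorded step exchanges one aromatic ring for another and says nothing about lengthening a chain on an oxygen on an aromatic ring. With nothing in the data pointing either way, the expected step is a 1.3-fold higher number from compound 2 to compound 3 (0.12 log units; within the scatter), not beyond the scatter. Compound 3 is therefore estimated at 0.25 nM, with a likely range from 0.08 nM to 0.8 nM.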

Compound 3, inhibition constant: 0.32 nM
Beside the measured number, compound 3's estimate is 1.3-fold (0.11 log units) below it; measured number inside the range.
By their numbers in this assay, from the lowest: compounds 1, 2 and 3 (each within the scatter of the next).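

In this assay, for the compounds shown here, the step of a 1.7-fold higher number from compound 2 to compound 3 (0.23 log units; within the scatter) gives the first reading of a change on the saturated chain carbon bound to an oxygen on an aromatic ring, and ethyl in place of hydrogen at this place, which turns methoxy into propoxy, leaves the number within the scatter. The step of a 1.8-fold higher number from compound 1 to compound 3 (0.25 log units; within the scatter) is also within the scatter, so these values do not separate 4-propoxypyrimidin-2-yl from pyrazin-2-yl on the amine nitrogen in a ring. No supporting measurement is available to explain these results.

The compounds shown leave open whether the numbers would stay this close with a longer chain, such as hexyloxy, on that oxygen. They also leave open what a propoxy chain ending in an amine or a carboxylic acid would give.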